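This account rests on a few compounds, and the source may have more. Where it says the series, first, only, none or still open, it means among the compounds named here.

Of the compounds shown here, three sharing one core have been measured in a physicochemical assay for lipophilicity, using the shake flask method, in phosphate buffer, measured as octanol-water partition, with a stated time of 30 min, at pH 7.4; on this read-out lower numbers stand for lower lipophilicity and higher numbers for higher lipophilicity: compound 1 `Fc1ccc2c(c1CNc1ncc(Oc3ccccc3)c3nncn13)CCO2` gives 3.5, compound 2 `O=C(Nc1cnc(NCc2c(F)ccc3c2CCO3)n2cnnc12)c1cccnc1` gives 2, and compound 3 `O=C(Nc1cnc(NCc2c(F)ccc3c2CCO3)n2cnnc12)c1ccccc1` gives 3. Compound 3 therefore sits in the middle of the three.

Compound 4 `Fc1ccc2c(c1CNc1ncc(Nc3ccccc3)c3nncn13)CCO2` has not yet been measured. It differs from compound 3 in one place: phenyl in place of benzoyl on a nitrogen on an aromatic ring. This is phenyl in place of benzoyl on a nitrogen on an aromatic ring, so benzamido becomes anilino.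

Among the measured compounds shown here, no measured step makes this exact change, so the guidance is indirect. The closest is a number 0.50 log units lower from compound 1 to compound 3 (beyond the scatter), where benzamido replaced phenoxy. Read in reverse, it suggests that removing benzamido may raise the number by a modest amount. The step of a number 1.50 log units lower from compound 1 to compound 2 (beyond the scatter) is large, but it brings in pyridin-3-yl, and a number 1.00 log units higher from compound 2 to compound 3 (beyond the scatter) shows that this swap alone matters, so it is a weaker guide.

A modest rise is expected, and the estimated change is a number 0.40 log units higher from compound 3 to compound 4 (beyond the scatter). For compound 4 the estimated value is 3.4, with an expected range from 2.9 to 3.9.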

Compound 4, distribution coefficient: 3.3
The estimate for compound 4 lay 0.10 log units above the measured number; low and high end bracket the measured number.
By their numbers in this assay, from the lowest: compound 2; then compounds 3, 4 and 1 (each within the scatter of the next, the first and the last beyond it).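

Putting anilino in place of phenoxy on this aromatic carbon gives a step that does not separate the two groups in this assay (a number 0.20 log units lower from compound 1 to compound 4 (within the scatter)), so here a nitrogen link and an oxygen link to the phenyl ring read alike. Taking the carbonyl out of benzamido to leave anilino also stays inside the noise (a number 0.30 log units higher from compound 3 to compound 4 (within the scatter)), whereas replacing (pyridin-3-yl)carbonyl with phenyl on the same nitrogen gives a number 1.30 log units higher from compound 2 to compound 4 (beyond the scatter), which leaves compound 2 clearly apart from compound 4. No measurement shown here explains these numbers.

Still open, going by these compounds, is whether pyridin-3-yl in place of the phenyl of anilino would lower the number without any carbonyl present. Equally open, on these data alone, is how a saturated amine such as piperidine, or a carboxylic acid, would read on this aromatic carbon.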